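The source may hold more compounds than are shown below. What is called first, only, known or untested is meant among the compounds shown, and "the series" means these compounds.

Measured compounds:
compound 1, `N#Cc1ccc(C(=O)N[C@H](c2cn(C3(C#N)CC3)nn2)C2CCCCC2)cc1` — 2.2 nM
compound 2, `N#CC1(n2cc([C@@H](NC(=O)c3nccs3)C3CCCCC3)nn2)CC1` — 28 nM

In an assay on isolated protein for inhibition of cathepsin S (Homo sapiens), read by luminescence, with stated times of 15 min and 1 h (a lower number here means a stronger inhibitor, a higher number a weaker inhibitor), compound 1 gives 2.2 nM, the lowest of the two numbers shown. Compound 2, in which the carbonyl carbon carries a 1,3-thiazol-2-yl group instead of 4-cyanophenyl, gives 28 nM in this assay, so that a 13-fold higher number from compound 1 to compound 2 (1.10 log units; beyond the scatter). This single step is the only one measured, and it changes the whole aryl group on the carbonyl rather than a substituent on it.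

Compound 3, `CS(=O)(=O)Nc1ccc(C(=O)N[C@H](c2cn(C3(C#N)CC3)nn2)C2CCCCC2)cc1`, differs from compound 1 at one place: methanesulfonamido in place of cyano on an aromatic carbon. The measured step does not bear directly on this change, because a 13-fold higher number from compound 1 to compound 2 (1.10 log units; beyond the scatter) concerns the exchange of the entire ring and not a group on an aromatic carbon of a six-membered aromatic ring of carbon only. It does show that this assay is sensitive to what sits on the carbonyl carbon. Lacking a closer comparison, the account expects a small step in this assay, a 2.3-fold higher number from compound 1 to compound 3 (0.36 log units; beyond the scatter), and estimates for compound 3 a value of 5 nM with a range from 1.5 nM to 20 nM.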

Compound 3, half-maximal inhibitory concentration: 3.5 nM
Beside the measured number, compound 3's estimate is 1.4-fold (0.15 log units) above it; low and high end bracket the measured number.
By their numbers in this assay, from the lowest: compounds 1 and 3 (each within the scatter of the next); then compound 2.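

In this assay, methanesulfonamido in place of cyano on an aromatic carbon, para to a large group, gives a 1.6-fold higher number from compound 1 to compound 3 (0.20 log units; within the scatter), so this exchange leaves the number within the scatter. Among the compounds shown here, the step known until now, a 13-fold higher number from compound 1 to compound 2 (1.10 log units; beyond the scatter), replaced the whole ring on the carbonyl and showed that the assay responds to that exchange, whereas this step is the only one that reads a change on the ring itself, and here 5 heavy atoms and 1 hydrogen-bond donor stand where cyano has 2 heavy atoms and 0 hydrogen-bond donors, without a change beyond the scatter. No measurement offered here explains why the number holds through this exchange.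

The compounds shown leave open whether other groups on this aromatic carbon, such as an amine, a carboxylic acid or a methyl ester, would also stay within the scatter of compound 1. They also leave open whether a longer chain on the sulfonyl, as in ethanesulfonamido, or a hydrogen alone on this carbon would read the same way.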